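The source may hold more compounds than are shown below. What is called first, only, known or untested is meant among the compounds shown, and "the series" means these compounds.

Measured compounds:
- compound 1, `Cc1ccc(CC(COC(=O)C(C)(C)C)CN(O)/C(S)=N/Cc2ccc(NS(C)(=O)=O)c(F)c2)cc1C`: 212 nM
- compound 2, `COc1cc(C/N=C(\S)N(O)CC(COC(=O)C(C)(C)C)Cc2ccc(C)c(C)c2)ccc1NS(C)(=O)=O`: 396 nM

Among the compounds with values here, in an assay on CHO cells for binding affinity to transient receptor potential cation channel subfamily V member 1 (Rattus norvegicus) (a lower number here means a stronger inhibitor, a higher number a weaker inhibitor), compound 1 gives 212 nM, the lowest of the two numbers known; compound 2 gives 396 nM, and the step of a 1.9-fold higher number from compound 1 to compound 2 (0.27 log units; within the scatter) stays within the scatter, so the two cannot be ranked. The unmeasured compound 3, `Cc1ccc(CC(COC(=O)C(C)(C)C)CN(O)/C(S)=N/Cc2ccc(NS(C)(=O)=O)cc2F)cc1C`, differs from compound 1 by 2-fluoro-4-(methanesulfonamido)phenyl in place of 3-fluoro-4-(methanesulfonamido)phenyl on a saturated chain carbon bound to a double-bonded nitrogen. Within the data shown here, no measured step changes the same thing: the only known step, a 1.9-fold higher number from compound 1 to compound 2 (0.27 log units; within the scatter), swaps one group for another on that ring and is small, which shows only that this ring tolerates a change there without a large shift in this assay. On that basis the step from compound 1 to compound 3 is expected to be modest, a 1.5-fold higher number from compound 1 to compound 3 (0.18 log units; within the scatter), with no clear direction beyond the scatter. Compound 3 is therefore estimated at 320 nM, in a range from 110 nM to 950 nM.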

Compound 3, inhibition constant: 620 nM
For compound 3 the middle estimate is 1.9-fold (0.29 log units) below the measured one; measured number inside the range.
By their numbers in this assay, from the lowest: compounds 1, 2 and 3 (each within the scatter of the next, the first and the last beyond it).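

In this assay, moving the fluorine, so that 2-fluoro-4-(methanesulfonamido)phenyl stands in place of 3-fluoro-4-(methanesulfonamido)phenyl, gives a 2.9-fold higher number from compound 1 to compound 3 (0.47 log units; beyond the scatter) and so clears the scatter, while the earlier change of group on this ring gave only a 1.9-fold higher number from compound 1 to compound 2 (0.27 log units; within the scatter) and did not. The ring therefore responds to where the fluorine sits even though the atoms and the counts of donors and acceptors stay the same, something the first two compounds could not show. Nothing at hand explains this shift.

As far as these compounds go, it remains open whether a chlorine or a nitrile in place of the fluorine would follow the same course, or whether a ring with hydrogen there would bind better or worse than compound 1. From the compounds shown here alone, the effect of the same move on the rest of the shared core also remains untested here.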